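Selenol to Methylsulfanyl on a Fused Bicyclic Core

The source may hold more compounds than are shown below. What is called first, only, known or untested is meant among the compounds shown, and "the series" means these compounds.

Compound 1 `[SeH]c1nc(NCc2ccccc2)c2cccnc2n1` carries a benzylamine arm on the shared core. In a functional assay on HTB-54 cells (Homo sapiens) for cytotoxicity, read by MTT assay, with a stated time of 72 h (on this read-out lower numbers stand for stronger inhibition of growth and higher numbers for weaker inhibition of growth), compound 1 gives only a limit, > 100000 nM, and no number. Compound 2 `[SeH]c1nc([SeH])c2cccnc2n1` gives 4030 nM in this assay. Compound 3 `CSc1nc(NCc2ccccc2)c2cccnc2n1` differs from compound 1 by a group of 2 heavy atoms (1 carbon, 1 sulfur; no ring) in place of one selenium atom, on an aromatic carbon, between two ring nitrogen atoms. Within the data shown here, no measured step covers such a change, and compound 1 sits at the limit (the limit of > 100000 nM in this assay, at which 1 of the 2 values shown sits). Compound 3 is therefore expected near 100000 nM, within 30000 nM to 300000 nM, an estimated step of a number no higher from compound 1 to compound 3 (the limit leaves the size open).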

Compound 3, concentration for 50% growth inhibition: 5080 nM
Compound 3: the middle estimate sits 20-fold (1.29 log units) above what was measured; the whole stated range lies above it.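

In this assay the change from selenium to methylsulfanyl on the aromatic carbon between two ring nitrogen atoms, with the benzylamine arm kept, gives an at least 19-fold lower number from compound 1 to compound 3 (1.29 log units; beyond the scatter) and shows that the group at this position matters. Compound 1 gives > 100000 nM as a limit of the assay and not a number. The full size of the step stays open: the limit of > 100000 nM in this assay, at which 1 of the 3 values shown sits.

The compounds shown leave open what a thiol, a methylselanyl group or a longer chain such as ethylsulfanyl would give at this position. They also leave open whether the sulfur or the added methyl goes with the step.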